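Sulfonyl swap at the tolerance limit in HEK293 cells

The source may hold more compounds than are shown below. What is called first, only, known or untested is meant among the compounds shown, and "the series" means these compounds.

Measured in a functional assay on HEK293 cells (Homo sapiens) for cytotoxicity; a lower number here means that less compound is tolerated, a higher number that more compound is tolerated:
- compound 1 `COc1ccc([C@H]2CC(=O)N(c3cccc(NS(=O)(=O)c4ccccc4F)c3)C2)cc1OC1CCCC1` gives > 10000 nM as a limit
- compound 2 `COc1ccc([C@H]2CC(=O)N(c3cccc(NS(=O)(=O)c4cccc(F)c4)c3)C2)cc1OC1CCCC1` gives > 10000 nM as a limit
- compound 3 `COc1ccc([C@H]2CC(=O)N(c3cccc(NS(=O)(=O)c4ccccc4Br)c3)C2)cc1OC1CCCC1` gives > 10000 nM as a limit

Compound 3 stands at a limit and not at a number. It shares that position with the other two compounds, as the limit of > 10000 nM in this assay, at which 3 of the 3 values shown sit, shows.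

Compound 4 `COc1ccc([C@H]2CC(=O)N(c3cccc(NS(=O)(=O)c4cc(Br)c(Cl)s4)c3)C2)cc1OC1CCCC1` keeps the shared core and changes one group on a sulfonyl sulfur, with 4-bromo-5-chlorothiophen-2-yl in place of 2-bromophenyl on a sulfonyl sulfur is the whole difference.

Going by the values given here, three measured steps bear on this change, since each alters the group on the sulfonyl sulfur. They are a step that the two limits leave unreadable from compound 1 to compound 2 and a step that the two limits leave unreadable from compound 1 to compound 3 and a step that the two limits leave unreadable from compound 2 to compound 3 and none of them has a readable size. Among the compounds with values here, none of the measured compounds carries a five-membered aromatic ring with 1 hetero atom, so the lower side of the expectation stays open.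

No change beyond the scatter is expected in this assay on this evidence. The expected step is a step that the limit leaves unreadable from compound 3 to compound 4 and it rests on the limit that compound 3 holds at > 10000 nM in this series. For compound 4 the estimated value is 12000 nM with an expected range from 5000 nM to 30000 nM and a reading at the limit is the likeliest outcome.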

Compound 4, half-maximal cytotoxic concentration: > 10000 nM
Compound 4 ended at the assay's limit; the forecaster's own chance of this, stated with the estimate: 80%; the middle value lies beyond the limit too.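

In this assay compound 4 gives > 10000 nM as a limit. No size can be read for its steps from compound 1, compound 2 or compound 3, which hold the same position: the limit of > 10000 nM in this assay, at which 4 of the 4 values shown sit.

The compounds shown leave open whether any group on the sulfonyl sulfur would give a reading under this limit.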